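This account rests on a few compounds, and the source may have more. Where it says the series, first, only, none or still open, it means among the compounds named here.

Of the compounds shown here, two have so far been measured in a functional assay on HeLa cells (Homo sapiens) for inhibition, read by CCK-8 assay, with a stated time of 72 h; on this read-out higher numbers stand for weaker inhibition and lower numbers for stronger inhibition. Compound 1 `O=C(/C=C/c1cccnc1)NCCCCCCCc1ccc(S(=O)(=O)Nc2ccccc2)cc1` gives 223 nM, while compound 2 `O=C(/C=C/c1cccnc1)NCCCCCCc1cccc(S(=O)(=O)Nc2ccccc2)c1` gives 30.4 nM, the lower of the two numbers, and its gap to compound 1 lies beyond the scatter. Compound 3 `O=C(/C=C/c1cccnc1)NCCCCCCc1cccc(S(=O)(=O)Nc2ccc(F)c(Cl)c2)c1` has not yet been measured; it differs from compound 2 by 3-chloro-4-fluorophenyl in place of phenyl on a sulfonamide nitrogen. Within the data shown here, no measured pair shows this same change, so its size cannot be read from the data. A step of a 1.2-fold lower number from compound 2 to compound 3 (0.08 log units; within the scatter) is expected, within the scatter. Compound 3 is therefore estimated at 25 nM, in the range 8 nM to 80 nM.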

Compound 3, half-maximal inhibitory concentration: 385 nM
Beside the measured number, compound 3's estimate is 15-fold (1.19 log units) below it; measured number above the stated range.
By their numbers in this assay, from the lowest: compound 2; then compounds 1 and 3 (each within the scatter of the next).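

In this assay putting 3-chloro-4-fluorophenyl in place of phenyl on the sulfonamide nitrogen gives a 13-fold higher number from compound 2 to compound 3 (1.10 log units; beyond the scatter) and so clearly weaker inhibition. This shows that the ring on this nitrogen is not a free place for change: adding these two halogens costs much of the inhibition seen with compound 2. Nothing available explains this loss. Still open, on these data alone, is whether 4-fluorophenyl or 3-chlorophenyl alone would bring the same loss. Also open, as far as these compounds go, is how a methoxyphenyl group on this nitrogen would compare.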